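The source may report more compounds than this note shows. Statements on the series, on what has been measured and on what is new or still open speak of the compounds shown alone.

Measured compounds:
Compound 1 `COc1ccc(-c2cc(/C=C/C(=O)c3ccc(N)cc3)[nH]n2)cc1` gives 88% in a functional assay on RXF 393 cells (Homo sapiens) for cytotoxicity, read by sulforhodamine B assay, with a stated time of 48 h, tested at 0.1 uM; on this read-out higher numbers stand for a weaker effect at the one concentration tested and lower numbers for a stronger effect.
Compound 2 `COc1ccc(-c2cc(/C=C/C(=O)c3ccc(N)cc3)[nH]n2)cc1OC` gives 92% in this assay.
Compound 3 `COc1cc(C(=O)/C=C/c2cc(-c3cc(OC)c(OC)c(OC)c3)n[nH]2)cc(OC)c1OC` gives 88% in this assay.

Compound 2 and compound 1 differ in one place, (hydrogen in place of methoxy on an aromatic carbon), and this change produces a number 4 percentage points lower from compound 2 to compound 1 (within the scatter). Compound 3 has a different core from compound 2; how the two cores differ is not broken down here. At the digits reported, compound 3 stands level with compound 1, and its gap to compound 2 is within the scatter of repeated measurements.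

Compound 4 `COc1ccc(-c2cc(/C=C/C(=O)c3cc(OC)c(OC)c(OC)c3)[nH]n2)cc1OC` has not yet been measured. It differs from compound 3 by hydrogen in place of methoxy on an aromatic carbon. This is the same kind of change as that from compound 2 to compound 1, though the place is not identical: in compound 3 the aromatic carbon is also meta to a methoxy group (2 heavy atoms). Because the earlier step of a number 4 percentage points lower from compound 2 to compound 1 (within the scatter) was small, the step from compound 3 to compound 4 in this assay is expected to be a number 2 percentage points lower from compound 3 to compound 4 (within the scatter). Compound 4 is therefore estimated at 86%, expected to fall between 76% and 96%.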

Compound 4, a percentage reported as activity, at one concentration (the size of the read-out at that concentration, not a potency): 102%
For compound 4 the middle estimate is 16 percentage points below the measured one; the measured number lies above the stated range.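

In this assay, hydrogen in place of methoxy on an aromatic carbon gave a number 14 percentage points higher from compound 3 to compound 4 (beyond the scatter), which means a weaker effect at the one concentration tested. For the compounds shown here, the change therefore did not carry over from one core to the other with the same size: the same change on two cores in this assay, a number 4 percentage points lower (within the scatter) from compound 2 to compound 1 and a number 14 percentage points higher (beyond the scatter) from compound 3 to compound 4, 18 percentage points apart, beyond the scatter of two such steps This does not explain the difference or predict the step on any further core: it rests on only two pairs at a single concentration, and because the place of the change is not identical in the two pairs, the influence of the core cannot be separated from that of the place.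

The compounds shown leave open whether a hydroxy group or a chlorine atom at the same place would give a number closer to that of the methoxy compound or the hydrogen compound on either core. They also leave open whether the gap between the two steps would persist at other concentrations or on other cell lines.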